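This account rests on a few compounds, and the source may have more. Where it says the series, first, only, none or still open, it means among the compounds named here.

Measured so far in a functional assay on EBC-1 cells (Homo sapiens) for antiproliferative activity, with a stated time of 72 h; on this read-out higher numbers stand for weaker inhibition and lower numbers for stronger inhibition:
compound 1, `Cn1cc(-c2cc(F)c3ncc(Cc4ccc5ncccc5c4)n3c2)cn1`, gives 0.27 nM;
compound 2, `COc1ccc(-c2cc(F)c3ncc(Cc4ccc5ncccc5c4)n3c2)cc1F`, gives 407 nM.

Among the compounds with values here, compound 2 holds the highest of the two numbers; its only neighbour is compound 1, and the single step available, a 1500-fold higher number from compound 1 to compound 2 (3.18 log units; beyond the scatter), was large and beyond the scatter.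

Compound 3, `O=C(NC1CCOCC1)c1ccc(-c2cc(F)c3ncc(Cc4ccc5ncccc5c4)n3c2)cc1F`, is not yet measured. It differs from compound 2 by (oxan-4-yl)carbamoyl in place of methoxy on an aromatic carbon. No measured step concerns this change: the one step shown swaps the whole ring on the shared core, not a substituent on the 3-fluoro-4-methoxyphenyl ring, so it gives direction only loosely. For this assay a lower number than compound 2 is expected, though with wide uncertainty. The estimate for compound 3 is 100 nM, range 10 nM to 1500 nM, which corresponds to an expected step of a 4.1-fold lower number from compound 2 to compound 3 (0.61 log units; beyond the scatter).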

Compound 3, half-maximal inhibitory concentration: 70.5 nM
The estimate for compound 3 lay 1.4-fold (0.15 log units) above the measured number; the range from low to high includes it.
By their numbers in this assay, from the lowest: compound 1; then compound 3; then compound 2.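

In this assay, the position para to a large group on the fluorinated phenyl ring accepts a far bulkier substituent than methoxy without loss: the change to (oxan-4-yl)carbamoyl gives a 5.8-fold lower number from compound 2 to compound 3 (0.76 log units; beyond the scatter), a modest gain. The earlier step swapped the whole ring on the shared core, whereas this one shows that a substituent on the ring itself can move the number in the direction of stronger inhibition, yet compound 3 at 70.5 nM still stands well above compound 1 at 0.27 nM. Nothing available explains the gain.

The compounds shown do not separate the contribution of the amide carbonyl and the amide hydrogen from that of the oxane ring. Going by these compounds, a plain primary carboxamide, a carboxylic acid or a morpholine amide at this position would address that, and the role of the fluoro group also remains open.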